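The source may hold more compounds than are shown below. What is called first, only, known or untested is meant among the compounds shown, and "the series" means these compounds.

Going by the values given here, compound 3, `O=C(/C=C/c1cn([C@H]2C[C@H](C(=O)O)N(Cc3ccccc3)C2)nn1)NO`, is the one compound of the three measured that returns a number: in an assay on Sf9 cells for inhibition of histone deacetylase 11 (Homo sapiens), read by fluorescence, tested at 0.5 uM (on this read-out lower numbers stand for less inhibition and higher numbers for more inhibition at the one concentration tested (going by the name of the read-out)), compound 3 gives 14%. Compound 1, `O=C(NO)c1ccc(-c2cn([C@@H]3C[C@H](C(=O)O)N(Cc4ccccc4)C3)nn2)cc1`, sits at a limit of this assay, giving < 10%. Compound 2, `O=C(NO)c1cccc(-c2cn([C@@H]3C[C@H](C(=O)O)N(Cc4ccccc4)C3)nn2)c1`, likewise sits at a limit, giving < 10%. The step that the two limits leave unreadable from compound 1 to compound 2 therefore cannot be read, as both values rest on (the limit of < 10% in this assay, at which 2 of the 3 values shown sit).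

Compound 4, `O=C(/C=C/c1cn([C@@H]2C[C@H](C(=O)O)N(Cc3ccccc3)C2)nn1)NO`, is the next compound; it differs from compound 3 in that (the two compounds have the same atoms and bonds and differ only in configuration as drawn: 1 of 3 stereo elements differ; a stereocentre at a saturated ring carbon is drawn S in compound 3 and R in compound 4). Among the compounds with values here, no measured step concerns a change of configuration, so nothing among the measured pairs bears on this one. Compound 4 is accordingly expected to stay close to compound 3, with a step of a number 2 percentage points lower from compound 3 to compound 4 (within the scatter) not beyond the usual scatter. Compound 4 is estimated at 12%, within a range of 3% to 25%.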

Compound 4, a percentage reported as inhibition, at one concentration (the size of the read-out at that concentration, not a potency): < 10%
Compound 4 gave a limit, no number (the forecaster's own chance of this, stated with the estimate: 40%); at least 2 percentage points between middle value and limit.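

In this assay, going by these compounds alone, configuration at the saturated ring carbon is the only thing that changes, and going from S to R gives a number at least 4 percentage points lower from compound 3 to compound 4 (that floor lies within the scatter). Within the data shown here, this is the first reading on configuration at this position, and since the value of compound 4 is a limit, it shows no separation of the two forms beyond the scatter. The steps to compound 4 from compound 1 and compound 2 cannot be read: the limit of < 10% in this assay, at which 3 of the 4 values shown sit.

As far as these compounds go, whether a primary amide or a methyl ester in place of the carboxylic acid would lift either form clear of that limit stays open.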